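The source may hold more compounds than are shown below. What is called first, only, known or untested is meant among the compounds shown, and "the series" means these compounds.

Compound 1 `COc1cc(-n2ncnc2-c2ccc(F)cc2)cc(OC)c1OC`: > 10000 nM
Compound 2 `COc1cc(-c2ncnn2-c2ccc(F)cc2)cc(OC)c1OC`: > 10000 nM

Both compounds were tested in a functional assay on HeLa cells (Homo sapiens) for antiproliferative activity, read by MTT assay, with a stated time of 72 h; on this read-out higher numbers stand for weaker inhibition and lower numbers for stronger inhibition. For compound 1 the result > 10000 nM is a limit of the assay, not a measured number. For compound 2 the result > 10000 nM is likewise a limit. Among the compounds with values here, compound 1 therefore stands at the edge of what this assay can report, and the same is true of the only other value shown, so nothing here places one compound ahead of the other: the limit of > 10000 nM in this assay, at which 2 of the 2 values shown sit.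

Compound 3 `COc1cccc(-c2ncnn2-c2cc(OC)c(OC)c(OC)c2)c1` has not yet been measured in this assay. It differs from compound 1 in one place: 3-methoxyphenyl in place of 4-fluorophenyl on an aromatic carbon.

Within the data shown here, no step between two measured compounds exists here, so there is no measured change of this kind to lean on. Given that compound 1 sits at the limit described by the limit of > 10000 nM in this assay, at which 2 of the 2 values shown sit, compound 3 is expected to remain near that limit, with a step that the limit leaves unreadable from compound 1 to compound 3 that is not expected to exceed the usual scatter. The estimate for compound 3 in this assay is 12000 nM, with a range from 2000 nM to 50000 nM.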

Compound 3, half-maximal inhibitory concentration: > 10000 nM
Compound 3: only a limit was reported (the forecaster's own chance of this, stated with the estimate: 70%); the middle value is on the limit's open side.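

In this assay compound 3 gives > 10000 nM as a limit of the assay, not a number. Within the data shown here, compound 1 also stands at a limit, so no step from compound 1 to compound 3 can be read. The compounds shown leave open whether swapping 4-fluorophenyl for 3-methoxyphenyl changes activity at all, because every result rests at the same edge: the limit of > 10000 nM in this assay, at which 3 of the 3 values shown sit.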